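The source may hold more compounds than are shown below. What is called first, only, known or untested is meant among the compounds shown, and "the series" means these compounds.

Measured compounds:
- compound 1, `CC(=O)Oc1ccccc1C(=O)O[C@H]1CO[C@H]2[C@@H]1OC[C@H]2O`: 0.055 h
- compound 2, `CC(=O)Oc1ccccc1C(=O)O[C@H]1CO[C@H]2[C@@H]1OC[C@H]2OC(=O)c1cccc(O)c1`: 0.0183 h

Both compounds were examined in an ADME assay on a cell-free system (plasma, Homo sapiens) for metabolic stability, with Plasma (Rattus norvegicus) as the target, read by HPLC, at pH 7.4; a higher number here means that the compound lasts longer, a lower number that the compound disappears faster. Compound 1, with a free hydroxy on its core, gives 0.055 h, the higher of the two numbers. Compound 2 carries an added ester on that oxygen and gives 0.0183 h; the step is a 3.0-fold lower number from compound 1 to compound 2 (0.48 log units; beyond the scatter), a modest drop that lies beyond the scatter.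

The unmeasured compound 3, `CC(=O)Oc1ccccc1C(=O)O[C@H]1CO[C@H]2[C@@H]1OC[C@H]2OC(=O)c1ccncc1`, is related to compound 1 by (pyridin-4-yl)carbonyl in place of hydrogen on an oxygen on a saturated carbon. Going by the values given here, the only step that bears on it is a 3.0-fold lower number from compound 1 to compound 2 (0.48 log units; beyond the scatter), in which a different carbonyl group entered at the same oxygen on a saturated carbon. Compound 3 receives a carbonyl group of the same kind at the same place, so a step of similar direction and size is expected in this assay, that is a lower number beyond the scatter, though a pyridine ring rather than a hydroxyphenyl ring leaves the exact size uncertain.

Compound 3 is therefore estimated at 0.022 h, with a range from 0.01 h to 0.05 h, which corresponds to an expected step of a 2.5-fold lower number from compound 1 to compound 3 (0.40 log units; beyond the scatter).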

Compound 3, half-life: 0.0617 h
Beside the measured number, compound 3's estimate is 2.8-fold (0.45 log units) below it, outside the stated range (above it).
By their numbers in this assay, from the lowest: compound 2; then compounds 1 and 3 (each within the scatter of the next).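

In this assay, placing (pyridin-4-yl)carbonyl on the oxygen on a saturated carbon gives a 1.1-fold higher number from compound 1 to compound 3 (0.05 log units; within the scatter) and so shows that an added ester at this oxygen does not in itself bring the lower number seen with compound 2. The group on the carbonyl carbon separates the two esters: pyridin-4-yl in place of 3-hydroxyphenyl gives a 3.4-fold higher number from compound 2 to compound 3 (0.53 log units; beyond the scatter) and shows that, at this position, the outcome depends on what the carbonyl carries and not only on the carbonyl being there. Nothing available explains why these two rings differ.

The compounds shown leave open whether the hydroxy on the 3-hydroxyphenyl ring of compound 2 or the nitrogen in the pyridin-4-yl ring of compound 3 accounts for the gap, and a plain phenyl ring on the same carbonyl would be needed to separate the two. They also leave open how this oxygen would behave with a non-aromatic group on the carbonyl, such as a short alkyl chain or a chain bearing an amine, or whether other positions on the pyridine ring would give the same result.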